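Changing the side-chain amine of compound 3

A few compounds are considered here, and "the series" means these few. Any claim that something is new, unique, unknown or untested is made for them only; others in the source may bear on it.

Of the compounds shown here, three sharing one core have been tested in a functional assay on A549 cells (Homo sapiens) for antiproliferative activity, read by MTT assay, with a stated time of 72 h; a lower number here means a stronger inhibitor, a higher number a weaker inhibitor. Compound 1 `COc1cc2c(Nc3ccc(C#N)cc3)ncnc2cc1OCCCN(C)Cc1ccccc1` reaches only a limit of the assay, > 100000 nM. Compound 2 `CCOC(=O)C1CCN(CCCOc2cc3ncnc(Nc4ccc(C#N)cc4)c3cc2OC)CC1` gives 89900 nM, and compound 3 `COc1cc2c(Nc3ccc(C#N)cc3)ncnc2cc1OCCCN1CCC(N(C)C)CC1` gives 42400 nM, the lower of the two actual numbers.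

Compound 4 `COc1cc2c(Nc3ccc(C#N)cc3)ncnc2cc1OCCCN1CCN(C)CC1` carries 4-methylpiperazin-1-yl in place of the 4-(dimethylamino)piperidin-1-yl of compound 3, on a saturated chain carbon, three bonds along the chain from an oxygen on an aromatic ring: 4-methylpiperazin-1-yl in place of 4-(dimethylamino)piperidin-1-yl on a saturated chain carbon, three bonds along the chain from an oxygen on an aromatic ring.

Within the data shown here, two measured steps bear on this change: a 2.1-fold lower number from compound 2 to compound 3 (0.33 log units; beyond the scatter), and an at least 2.3-fold lower number from compound 1 to compound 3 (0.37 log units; beyond the scatter). The second is only a floor, since one end of it is a limit. Neither gives grounds to expect a large jump, so a small step is expected in this assay, more likely upward than downward, and perhaps none beyond the scatter. The expected change is a 1.3-fold higher number from compound 3 to compound 4 (0.11 log units; within the scatter). In this assay compound 4 is estimated at 55000 nM, within a range of 25000 nM to 110000 nM.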

Compound 4, half-maximal inhibitory concentration: 48800 nM
Estimate against measurement, compound 4: 1.1-fold (0.05 log units) above; the measured number falls inside the stated range.
By their numbers in this assay, from the lowest: compounds 3, 4 and 2 (each within the scatter of the next, the first and the last beyond it). At a limit, above all of these: compound 1.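

In this assay, putting 4-methylpiperazin-1-yl in place of 4-(dimethylamino)piperidin-1-yl on this chain carbon gives a 1.2-fold higher number from compound 3 to compound 4 (0.06 log units; within the scatter), so the two groups cannot be told apart here, even though the ring now holds a second hetero atom and the group is smaller. Set against the 4-(ethoxycarbonyl)piperidin-1-yl group, the new group gives a 1.8-fold lower number from compound 2 to compound 4 (0.27 log units; within the scatter), so this comparison also stays inside the usual variation between repeats. Compound 1 stands at a limit of the assay, not at a number, which makes an at least 2.0-fold lower number from compound 1 to compound 4 (0.31 log units; beyond the scatter) only a floor: the limit of > 100000 nM in this assay, at which 1 of the 4 values shown sits.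

The compounds shown leave open what a morpholin-4-yl or pyrrolidin-1-yl group would give at this place, or a longer chain carrying the 4-methylpiperazin-1-yl group. They also leave open whether changing this amine alone can ever lower the number by much.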